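Methyl in Place of Fluoro on the Shared Core

This account rests on a few compounds, and the source may have more. Where it says the series, first, only, none or still open, it means among the compounds named here.

Compound 1 `Clc1ccc(-c2csc(N/N=C/c3cccs3)n2)cc1` is the stronger of the two measured compounds: in a functional assay, read by spectrophotometry, with a stated time of 15 min, tested at 80 ug/mL (a higher number here means a stronger effect of the compound at the concentration tested, a lower number a weaker effect), compound 1 gives 96.6%. Compound 2 `Fc1ccc(-c2csc(N/N=C/c3cccs3)n2)cc1`, which carries fluoro in place of chloro on an aromatic carbon, gives 66.3% in this assay. That one step, a number 30.3 percentage points lower from compound 1 to compound 2 (beyond the scatter), is large and beyond the scatter, and it leaves compound 2 as the lowest of the two numbers shown, with compound 1 as its only neighbour.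

Compound 3 `Cc1ccc(-c2csc(N/N=C/c3cccs3)n2)cc1` has not yet been measured. It differs from compound 2 by methyl in place of fluoro on an aromatic carbon. For the measured compounds named here, the only step that bears on this change is the one from compound 1 to compound 2, which exchanged one halogen for another at the same place and cost a large amount of inhibition. Going by the values given here, no measured step shows methyl at this place, so the direction of the new step is uncertain; a moderate rise is expected, since compound 2 sits at the bottom of the range seen so far. Compound 3 is estimated at 80%, between 55% and 98%, an expected step of a number 13.7 percentage points higher from compound 2 to compound 3 (beyond the scatter).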

Compound 3, a percentage reported as inhibition, at one concentration (the size of the read-out at that concentration, not a potency): 97.8%
Estimate against measurement, compound 3: 17.8 percentage points below, within the range that was stated.
By their numbers in this assay, from the lowest: compound 2; then compounds 1 and 3 (each within the scatter of the next).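

In this assay, methyl in place of fluoro on the aromatic carbon para to a large group gives a number 31.5 percentage points higher from compound 2 to compound 3 (beyond the scatter) and so reverses, in size, the loss seen with the earlier halogen exchange, a number 30.3 percentage points lower from compound 1 to compound 2 (beyond the scatter) in the same place. Methyl in place of chloro gives a number 1.2 percentage points higher from compound 1 to compound 3 (within the scatter) and so separates neither compound from the other, which shows that a halogen is not needed here for a high read-out: among the three groups seen at this place, only fluoro stands apart, with compound 2 lower than both of the others by more than the scatter. Nothing measured here accounts for why fluoro differs from chloro and methyl, and the steps can be described only as numbers.

As far as these compounds go, it remains open whether the high read-out holds with other groups at this place, such as an amine, a carboxylic acid, a methoxy group or a longer alkyl chain. Each value is also a read-out at one concentration, so the compounds shown leave open how the effects of compound 1 and compound 3 would compare at other concentrations.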